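The source may hold more compounds than are shown below. What is called first, only, known or untested is meant among the compounds shown, and "the series" means these compounds.

Among the measured compounds shown here, compound 2, `Cc1ccc2nc(N3CCCc4ccc(F)cc4C3)cc(NCCN3CCNCC3)c2c1`, is the only compound of this pair with a number in an ADME assay on HEp-2 cells (Homo sapiens) for cytotoxicity, read by CCK-8 assay, with a stated time of 5 days; a lower number here means that less compound is tolerated, a higher number that more compound is tolerated: in this assay compound 2 gives 40000 nM. Its neighbour compound 1, `Cc1ccc2nc(N3CCCc4ccc(F)cc4C3)cc(NCCN)c2c1`, reaches only a limit in this assay, where compound 1 gives > 3200 nM. The step from compound 1 to compound 2, a step that the limit leaves unreadable from compound 1 to compound 2, therefore cannot be read as a size, which rests on (the limit of > 3200 nM in this assay, at which 1 of the 2 values shown sits).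

Compound 3, `CC(=O)NCCNc1cc(N2CCCc3ccc(F)cc3C2)nc2ccc(C)cc12`, differs from compound 2 in one place: acetamido in place of piperazin-1-yl on a saturated chain carbon, two bonds along the chain from a nitrogen on an aromatic ring. No measured step in this assay bears on this change, since the one step recorded, from compound 1 to compound 2, is hidden by a limit, and the exchange of a ring for a short open chain is not covered by any pair shown. There is thus no measured reason to expect a step beyond the scatter in either direction, and the tolerance of compound 2 is the only anchor.

On that basis compound 3 is expected to give about 40000 nM in this assay, within 12000 nM to 130000 nM, an estimated step of no change at the digits printed from compound 2 to compound 3 (within the scatter).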

Compound 3, half-maximal cytotoxic concentration: 66000 nM
For compound 3 the middle estimate is 1.7-fold (0.22 log units) below the measured one; low and high end bracket the measured number.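

In this assay, the change at this position has its first readable size: acetamido in place of piperazin-1-yl on a saturated chain carbon, two bonds along the chain from a nitrogen on an aromatic ring, gives a 1.7-fold higher number from compound 2 to compound 3 (0.22 log units; within the scatter). For these two compounds, then, an open acetamido end and a six-membered non-aromatic ring with 2 hetero atoms cannot be told apart in this read-out, although the change removes the ring and 6 heavy atoms give way to 4. The terminal amino compound still gives no number to set beside them, so the steps from compound 1 to compound 2 and to compound 3 cannot be read, and the size of placing acetyl on that amine nitrogen stays unknown, all of this resting on a limit: the limit of > 3200 nM in this assay, at which 1 of the 3 values shown sits.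

Left open is whether a morpholine ring, a carboxylic acid or a longer chain at this position would also stay within the scatter of compound 2 and compound 3. Also open, going by these compounds, is whether the same holds with another group in place of the fluoro-bearing ring system on the shared core.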